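From hydroxy to methoxy in a small series

The source may report more compounds than this note shows. Statements on the series, on what has been measured and on what is new or still open speak of the compounds shown alone.

In a functional assay on MDA-MB-231 cells (Homo sapiens) for cytotoxicity, read by sulforhodamine B assay, with a stated time of 3 days (a higher number here means that more compound is needed for the effect, a lower number that less compound is needed), compound 1 (`CCOCc1c(C)coc1-c1ccc2c(c1OC)CCCC2(C)C`) gives 42.7 uM, compound 2 (`COC(=O)c1c(C)coc1-c1ccc2c(c1OC)CCCC2(C)C`) gives 61 uM and compound 3 (`Cc1coc(-c2ccc3c(c2O)CCCC3(C)C)c1C(=O)O`) gives 24.7 uM. Compound 3 holds the lowest of these numbers, within the scatter of compound 1 and beyond it from compound 2. Compound 4 (`COc1c(-c2occ(C)c2C(=O)O)ccc2c1CCCC2(C)C`) differs from compound 3 by methyl in place of hydrogen on an oxygen on an aromatic ring, hydroxy to methoxy. Among the compounds with values here, no measured step covers this change. The only one available, a 1.4-fold higher number from compound 1 to compound 2 (0.15 log units; within the scatter), lies elsewhere, methoxycarbonyl in place of ethoxymethyl on an aromatic carbon, and stays within the scatter. Compound 1 and compound 2 both carry the methoxy group, so a slightly higher number is expected, without a step clearly beyond the scatter: a 1.7-fold higher number from compound 3 to compound 4 (0.23 log units; within the scatter). For compound 4 the estimated value is 42 uM, with an expected range of 18 uM to 95 uM.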

Compound 4, concentration for half-maximal effect: > 61 uM
Compound 4: only a limit was reported; the forecaster's own chance of this, stated with the estimate: 15%; middle value at least 1.4-fold (0.16 log units) away from the limit.
By their numbers in this assay, from the lowest: compounds 3, 1 and 2 (each within the scatter of the next, the first and the last beyond it).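

In this assay, within the data shown here, methyl in place of hydrogen on an oxygen on an aromatic ring gives the first direct reading of this change: an at least 2.4-fold higher number from compound 3 to compound 4 (0.39 log units; beyond the scatter) is an at least modest step, and that floor already lies beyond the scatter. Carboxy in place of ethoxymethyl on an aromatic carbon gives an at least 1.4-fold higher number from compound 1 to compound 4 (0.15 log units; that floor lies within the scatter) and hydrogen in place of methyl on an oxygen next to a carbonyl group gives a number no lower from compound 2 to compound 4 (the limit leaves the size open) and the size of that step cannot be read. The value of compound 4 is a limit: the limit of > 61 uM in this assay, at which 1 of the 4 values shown sits.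

On these data alone, the actual size of the methoxy step stays open. So does the effect of an ethoxy group on that oxygen, or of an amine in place of the hydroxy.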